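A few compounds are considered here, and "the series" means these few. Any claim that something is new, unique, unknown or untested is made for them only; others in the source may bear on it.

Working notes on the series in a functional assay on HepG2 cells (Homo sapiens) for cytotoxicity, read by MTT assay, with a stated time of 72 h; on this read-out higher numbers stand for weaker inhibition and lower numbers for stronger inhibition. Compound 1 `N#Cc1ccc(/C=N/NC(=O)Nc2cc3c(Nc4ccc(F)c(Cl)c4)ncnc3cc2O[C@H]2CCOC2)cc1` gives 26400 nM, compound 2 `COc1cc(/C=N/NC(=O)Nc2cc3c(Nc4ccc(F)c(Cl)c4)ncnc3cc2O[C@H]2CCOC2)cc(OC)c1OC` gives 31200 nM, and compound 3 `CCN(CC)c1ccc(/C=N/NC(=O)Nc2cc3c(Nc4ccc(F)c(Cl)c4)ncnc3cc2O[C@H]2CCOC2)c(O)c1` gives 15700 nM. Compound 3 therefore stands within the scatter of both other compounds, and nothing separates it from them.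

The next structure is compound 4 `O=C(N/N=C/c1ccc(O)cc1)Nc1cc2c(Nc3ccc(F)c(Cl)c3)ncnc2cc1O[C@H]1CCOC1`, with 4-hydroxyphenyl in place of 4-(diethylamino)-2-hydroxyphenyl on a carbon with a double bond to nitrogen.

All three measured steps exchange the group at this same place: a 1.2-fold higher number from compound 1 to compound 2 (0.07 log units; within the scatter), a 1.7-fold lower number from compound 1 to compound 3 (0.23 log units; within the scatter), and a 2.0-fold lower number from compound 2 to compound 3 (0.30 log units; within the scatter). None of them leaves the scatter, although the groups exchanged differ considerably. Among the measured compounds shown here, no measured compound carries 4-hydroxyphenyl, so this reading rests on the other groups alone.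

No step beyond the scatter is therefore expected, and the expected change is a 1.4-fold higher number from compound 3 to compound 4 (0.15 log units; within the scatter). The estimated value for compound 4 is 22000 nM, with an expected range from 11000 nM to 45000 nM.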

Compound 4, half-maximal inhibitory concentration: 70 nM
Estimate against measurement, compound 4: 310-fold (2.50 log units) above; the whole stated range lies above it.
By their numbers in this assay, from the lowest: compound 4; then compounds 3, 1 and 2 (each within the scatter of the next).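

At the carbon with a double bond to nitrogen, this position can carry very large steps in this assay: 4-hydroxyphenyl in place of 4-(diethylamino)-2-hydroxyphenyl gives (a 220-fold lower number from compound 3 to compound 4 (2.35 log units; beyond the scatter)), 4-hydroxyphenyl in place of 3,4,5-trimethoxyphenyl gives (a 450-fold lower number from compound 2 to compound 4 (2.65 log units; beyond the scatter)), and hydroxy in place of cyano on an aromatic carbon gives (a 380-fold lower number from compound 1 to compound 4 (2.58 log units; beyond the scatter)). The earlier groups stayed within the scatter of one another, whereas compound 4 now stands alone as the most potent of the four, and compound 3 shows that carrying a hydroxy group does not by itself produce such a number. Nothing available explains the size of these steps.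

On these data alone, it remains open whether 4-methoxyphenyl, 4-aminophenyl or unsubstituted phenyl at this place would side with compound 4 or with the other three. The compounds shown also cannot separate the effect of the diethylamino group from that of the 2-hydroxy group in compound 3.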